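The source may report more compounds than this note shows. Statements on the series, on what has been measured and on what is new or still open speak of the compounds shown alone.

Measured compounds:
compound 1 `Cn1ncc(Cl)c1-c1cc(C(=O)N[C@@H]2CN[C@H](CCN3CCC(O)CC3)C[C@H]2c2ccc(Cl)c(Cl)c2)oc1Cl` gives 5.99 nM
compound 2 `Cn1ncc(Cl)c1-c1cc(C(=O)N[C@@H]2CNCC[C@H]2c2ccc(C(F)(F)F)cc2)oc1Cl` gives 9.3 nM
compound 3 `CC(=O)NCC[C@@H]1C[C@@H](c2ccc(F)c(F)c2)[C@H](NC(=O)c2cc(-c3c(Cl)cnn3C)c(Cl)o2)CN1` gives 2.49 nM

All three were read in an assay for inhibition of RAC-alpha serine/threonine-protein kinase (Homo sapiens), read by HTRF, with a stated time of 1 h; a lower number here means a stronger inhibitor, a higher number a weaker inhibitor. Compound 1 stands at the second highest of the three numbers. Compound 2 sits close to it, with a gap that lies within the scatter, so no order between compound 1 and compound 2 can be stated. Compound 3 gives the lowest number, and its gap to compound 1 is beyond the scatter. The three compounds differ in more than one place at a time, so no single change can be followed between measured compounds.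

Compound 4 `C=CC[C@@H]1C[C@@H](c2ccc(Cl)c(Cl)c2)[C@H](NC(=O)c2cc(-c3c(Cl)cnn3C)c(Cl)o2)CN1` has not yet been measured. It differs from compound 1 in one place: vinyl in place of (4-hydroxypiperidin-1-yl)methyl on a saturated chain carbon bound to a saturated ring carbon. Within the data shown here, no measured pair isolates this change. Compound 2, which carries no chain at all at the corresponding position, and compound 3, which carries a different chain, both stay within a narrow band around compound 1, so a large shift in either direction is not expected. A small step toward a higher number, at the edge of the scatter, is expected, a 1.7-fold higher number from compound 1 to compound 4 (0.22 log units; within the scatter). The estimate for compound 4 in this assay is 10 nM, with a range from 3 nM to 35 nM.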

Compound 4, half-maximal inhibitory concentration: 12.4 nM
The estimate for compound 4 lay 1.2-fold (0.09 log units) below the measured number; low and high end bracket the measured number.
By their numbers in this assay, from the lowest: compound 3; then compounds 1, 2 and 4 (each within the scatter of the next, the first and the last beyond it).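

In this assay, among these compounds, vinyl in place of (4-hydroxypiperidin-1-yl)methyl on a saturated chain carbon bound to a saturated ring carbon gives a 2.1-fold higher number from compound 1 to compound 4 (0.32 log units; beyond the scatter) and is the first change at this position that can be followed on its own. The step is modest, so in this pair the six-membered ring, its nitrogen and its oxygen are not needed for a number in the low nanomolar range. Nothing at hand gives a reason for the step.

The compounds shown do not tell whether the step follows from losing the hydroxyl, the whole piperidine ring or the chain length. A primary amine, a carboxylic acid or a longer saturated alkyl chain in the same place would help to separate these readings.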